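A Five-Membered Ring Replaces a Six-Membered One

This account rests on a few compounds, and the source may have more. Where it says the series, first, only, none or still open, it means among the compounds named here.

Measured so far:
Compound 1, `CN1CCN(Nc2cccc3c2C[C@@H](CN(C)[C@H]2CCCc4cccnc42)NC3)CC1`, gives 85.8%
Compound 2, `CN1C[C@@H]2CN(c3cccc4c3C[C@H](CN(C)[C@H]3CCCc5cccnc53)NC4)C[C@@H]2C1`, gives 32.9%
Compound 3, `CN(C)C1CCN(c2cccc3c2C[C@H](CN(C)[C@H]2CCCc4cccnc42)NC3)CC1`, gives 70.2%

These values come from an ADME assay on microsomes from liver (Mus musculus) for metabolic stability, using NADPH, with a stated time of 10 min; a higher number here means that more of the compound is left, a lower number that less of the compound is left. Compound 3 stands second highest of the three: compound 1 lies beyond the scatter above it, while compound 2 lies well below, the step being a number 37.3 percentage points higher from compound 2 to compound 3 (beyond the scatter). Compound 4, `CN(C)[C@H]1CCN(c2cccc3c2C[C@H](CN(C)[C@H]2CCCc4cccnc42)NC3)C1`, differs from compound 3 in one place: 3-(dimethylamino)pyrrolidin-1-yl in place of 4-(dimethylamino)piperidin-1-yl on an aromatic carbon. Among the compounds with values here, only that step from compound 2 to compound 3 touches this place, and it was large; yet there two rings gave way to one, whereas here one ring simply becomes smaller, so a much gentler shift is expected. The step from compound 3 to compound 4 is expected to be a number 10.2 percentage points lower from compound 3 to compound 4 (beyond the scatter), a modest drop at most. Compound 4 is estimated at 60% in this assay, between 38% and 80%.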

Compound 4, percent of the compound remaining: 18.5%
Compound 4: middle estimate off by 41.5 percentage points, on the high side; the whole stated range lies above it.
By their numbers in this assay, from the lowest: compound 4; then compound 2; then compound 3; then compound 1.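

A change of one ring size at this aromatic carbon can move the result sharply: 3-(dimethylamino)pyrrolidin-1-yl in place of 4-(dimethylamino)piperidin-1-yl gives a number 51.7 percentage points lower from compound 3 to compound 4 (beyond the scatter) in this assay. The single five-membered ring also falls short of the two fused five-membered rings, with a number 14.4 percentage points lower from compound 2 to compound 4 (beyond the scatter) in the same assay. Nothing measured here accounts for these drops. From the compounds shown here alone, what stays open is whether the mirror-image 3-(dimethylamino)pyrrolidin-1-yl group would behave alike. Going by these compounds, how an azetidine ring carrying the same dimethylamino group would fare at this carbon also remains unknown.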